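A Dimethoxyphenyl Swap on the Shared Core

The source may report more compounds than this note shows. Statements on the series, on what has been measured and on what is new or still open speak of the compounds shown alone.

Of the compounds shown here, three have been read in a functional assay on PC-3 cells (Homo sapiens) for inhibition, read by sulforhodamine B assay; a higher number here means a weaker inhibitor of growth, a lower number a stronger inhibitor of growth. Compound 1 `COc1ccc(-c2ccc(-c3ccc(-c4nc5ccccc5[nH]4)cc3)cc2)cc1OC` gives 47100 nM, compound 2 `COc1ccc(-c2ccc(-c3ccc(-c4nc5c(O)cccc5[nH]4)cc3)cc2)cc1` gives 6610 nM, and compound 3 `CN(C)c1ccc(-c2ccc(-c3ccc(-c4nc5c(O)cccc5[nH]4)cc3)cc2)cc1` gives 8420 nM. Compound 3 therefore lies within the scatter of compound 2, while compound 1 stands well above it.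

Compound 4 `COc1ccc(-c2ccc(-c3ccc(-c4nc5c(O)cccc5[nH]4)cc3)cc2)cc1OC` keeps the core of compound 3 and carries 3,4-dimethoxyphenyl in place of 4-(dimethylamino)phenyl on an aromatic carbon, para to a large group: 3,4-dimethoxyphenyl in place of 4-(dimethylamino)phenyl on an aromatic carbon. Going by the values given here, the one measured step that bears directly on this change is a 1.3-fold higher number from compound 2 to compound 3 (0.11 log units; within the scatter), with dimethylamino in place of methoxy on an aromatic carbon, and it stays within the scatter. Compound 1 also carries 3,4-dimethoxyphenyl, but on a different core, so its 47100 nM says little about this step alone.

No move beyond the scatter is expected, and the estimated step is a 1.1-fold higher number from compound 3 to compound 4 (0.03 log units; within the scatter). For compound 4 the estimated value is 9000 nM, with an expected range from 3500 nM to 28000 nM.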

Compound 4, concentration for 50% growth inhibition: 1240 nM
Beside the measured number, compound 4's estimate is 7.3-fold (0.86 log units) above it; the measured number lies below the stated range.
By their numbers in this assay, from the lowest: compound 4; then compounds 2 and 3 (each within the scatter of the next); then compound 1.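

In this assay, this place on the aromatic ring, para to a large group, proves responsive: replacing 4-(dimethylamino)phenyl with 3,4-dimethoxyphenyl gives a 6.8-fold lower number from compound 3 to compound 4 (0.83 log units; beyond the scatter), whereas the earlier change of dimethylamino for methoxy gave only a 1.3-fold higher number from compound 2 to compound 3 (0.11 log units; within the scatter). Going by these compounds alone, the added methoxy in place of hydrogen accounts for a step beyond the scatter, a 5.3-fold lower number from compound 2 to compound 4 (0.73 log units; beyond the scatter), so the second methoxy matters where the single swap at the other group did not. With 3,4-dimethoxyphenyl held constant, hydroxy in place of hydrogen on the core gives a 38-fold lower number from compound 1 to compound 4 (1.58 log units; beyond the scatter), showing that the low number depends on the hydroxy as well as on the dimethoxy pattern.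

No supporting data explain why these steps arise. Going by these compounds, whether 3,4-diethoxyphenyl or 3,4-dihydroxyphenyl in the same place would keep this reading remains open.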